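Swapping the dichlorophenyl for methoxyphenyl on the ring carbon

The source may report more compounds than this note shows. Statements on the series, on what has been measured and on what is new or still open speak of the compounds shown alone.

Measured compounds:
compound 1 `CC1=C(C(=O)Nc2ccc(Br)cc2)C(c2ccc(Cl)cc2Cl)N=C(SCc2ccccc2Cl)N1` gives 3.1%
compound 2 `CC1=C(C(=O)Nc2ccc(Br)cc2)C(c2ccc(Cl)cc2Cl)N=C(SCc2cccc(Cl)c2)N1` gives 1.5%
compound 3 `CC1=C(C(=O)Nc2ccc(Br)cc2)C(c2ccc(Cl)cc2Cl)N=C(SCc2ccc(Cl)cc2)N1` gives 4.1%

All three were tested in a functional assay on the whole organism (artery, strain albino) with Rattus norvegicus as the target, with a stated time of 15 min, at a dose of 10 mg/kg by the oral route; on this read-out higher numbers stand for more inhibition at the one dose given (going by the name of the read-out) and lower numbers for less inhibition. Compound 2 sits at one end of the three numbers, yet both a number 1.6 percentage points lower from compound 1 to compound 2 (within the scatter) and a number 2.6 percentage points higher from compound 2 to compound 3 (within the scatter) lie within the scatter, so the three compounds cannot be told apart on these data. Compound 4 `COc1ccc(C2N=C(SCc3cccc(Cl)c3)NC(C)=C2C(=O)Nc2ccc(Br)cc2)cc1` differs from compound 2 by 4-methoxyphenyl in place of 2,4-dichlorophenyl on a saturated ring carbon. Among the measured compounds shown here, the three measured steps, including a number 1 percentage points higher from compound 1 to compound 3 (within the scatter), all move a chlorine around the benzyl ring rather than touching the saturated ring carbon, so no step directly informs this change, and each was within the scatter. Compound 4 is therefore expected to stay near the low numbers seen so far, about 3% with a range of -5% to 13%, which means an expected step of a number 1.5 percentage points higher from compound 2 to compound 4 (within the scatter).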

Compound 4, a percentage reported as inhibition, in the whole organism at one dose (the size of the read-out at that dose, not a potency): 3.1%
For compound 4 the middle estimate is 0.1 percentage points below the measured one; low and high end bracket the measured number.
By their numbers in this assay, from the lowest: compounds 2, 1, 4 and 3 (each within the scatter of the next).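

Among the compounds shown here, this is the first change on the saturated ring carbon rather than on the benzyl ring. In this assay, replacing 2,4-dichlorophenyl with 4-methoxyphenyl gives a number 1.6 percentage points higher from compound 2 to compound 4 (within the scatter), so both chlorines can leave this ring and an oxygen-bearing group can enter without the number moving beyond the scatter. Nothing available explains this result.

As far as these compounds go, it remains open whether a 4-aminophenyl or 4-carboxyphenyl group at this ring carbon would move the number beyond the scatter. From the compounds shown here alone, it is also open whether 4-methoxyphenyl would behave the same alongside the 2-chlorobenzyl or 4-chlorobenzyl sulfanyl group.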